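Swapping the aryl group on the hydrazone carbon

The source may report more compounds than this note shows. Statements on the series, on what has been measured and on what is new or still open speak of the compounds shown alone.

Compound 3 `CN(C)CCn1cnnc1-c1cc(Oc2ccc(NC(=O)N/N=C/c3c(O)ccc4ccccc34)cc2F)ccn1` gives 890 nM in a functional assay on NCI-H460 cells (Homo sapiens) for cytotoxicity, read by MTT assay, with a stated time of 72 h (on this read-out lower numbers stand for stronger inhibition and higher numbers for weaker inhibition), the lowest of the three numbers shown, though both others lie within the scatter of it: compound 1 `CN(C)CCn1cnnc1-c1cc(Oc2ccc(NC(=O)N/N=C/c3c[nH]c4ccccc34)cc2F)ccn1` gives 1630 nM and compound 2 `CN(C)CCn1cnnc1-c1cc(Oc2ccc(NC(=O)N/N=C/c3ccccc3)cc2F)ccn1` gives 1780 nM. Compound 4 `COc1cc(/C=N/NC(=O)Nc2ccc(Oc3ccnc(-c4nncn4CCN(C)C)c3)c(F)c2)ccc1O` differs from compound 3 by 4-hydroxy-3-methoxyphenyl in place of 2-hydroxynaphthalen-1-yl on a carbon with a double bond to nitrogen. The measured steps that exchange this same group all stayed small: a 1.1-fold higher number from compound 1 to compound 2 (0.04 log units; within the scatter), a 1.8-fold lower number from compound 1 to compound 3 (0.26 log units; within the scatter) and a 2.0-fold lower number from compound 2 to compound 3 (0.30 log units; within the scatter). Three quite different groups on that carbon thus gave numbers within the scatter of each other, so no step beyond the scatter is expected in this assay for compound 4, with a slight lean toward a higher number because compound 3 already holds the lowest value at 890 nM. Compound 4 is estimated at 1300 nM, between 500 nM and 3500 nM, a step of a 1.5-fold higher number from compound 3 to compound 4 (0.16 log units; within the scatter).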

Compound 4, half-maximal inhibitory concentration: 57 nM
For compound 4 the middle estimate is 23-fold (1.36 log units) above the measured one; measured number below the stated range.
By their numbers in this assay, from the lowest: compound 4; then compounds 3, 1 and 2 (each within the scatter of the next).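

In this assay, this position proves far from indifferent: 4-hydroxy-3-methoxyphenyl on the carbon with a double bond to nitrogen gives a 16-fold lower number from compound 3 to compound 4 (1.19 log units; beyond the scatter), a 31-fold lower number from compound 2 to compound 4 (1.49 log units; beyond the scatter) and a 29-fold lower number from compound 1 to compound 4 (1.46 log units; beyond the scatter). For the compounds shown here, the three earlier groups stayed within the scatter of their neighbours, so only this exchange shows that the group here can move the number strongly. Nothing available explains why this group behaves so differently. Which part of the group matters stays open: a 4-hydroxyphenyl or a 3-methoxyphenyl on the same carbon would separate the contributions of the hydroxyl and the methoxy.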